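A few compounds are considered here, and "the series" means these few. Any claim that something is new, unique, unknown or untested is made for them only; others in the source may bear on it.

Compound 3 `COc1ccc(F)cc1CNCCCNc1ccnc2cc(Cc3ccc(F)cc3)ccc12` was measured in a physicochemical assay for solubility, with a stated time of 18 h, at pH 7.4 (a higher number here means a more soluble compound, a lower number a less soluble compound), where compound 3 gives 4200 nM. Compound 1 `COc1ccc(F)cc1CNCCCNc1ccnc2cc(Cc3ccc(F)cc3Cl)ccc12` gives 4200 nM in this assay, and compound 2 `COc1ccc(F)cc1CNCCCNc1ccnc2cc(-c3ccc(F)cc3)ccc12` gives 32000 nM. Compound 3 therefore sits level with compound 1, the two together forming the lowest pair of the three numbers, while compound 2 stands a 7.6-fold lower number from compound 2 to compound 3 (0.88 log units; beyond the scatter) away in the other direction.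

Compound 4 `COc1ccc(F)cc1CNCCCNc1ccnc2cc(-c3cccc4ccccc34)ccc12` has not yet been measured. Its difference from compound 3 is naphthalen-1-yl in place of 4-fluorobenzyl on an aromatic carbon. Among the compounds with values here, two measured steps bear on this. The step of a 7.6-fold lower number from compound 2 to compound 3 (0.88 log units; beyond the scatter) shows that inserting a one-carbon linker between the two rings moved the number by a modest amount; the step of no change at the digits printed from compound 1 to compound 3 (within the scatter) shows that a single halogen on the outer ring did nothing beyond the scatter. Within the data shown here, compound 4 removes the linker, as in compound 2, but brings in a second fused ring for which no precedent exists here, so the two influences may pull against each other. Compound 4 is therefore expected to change by a 1.1-fold lower number from compound 3 to compound 4 (0.02 log units; within the scatter), giving an estimate of 4000 nM, within a range from 1000 nM to 16000 nM.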

Compound 4, solubility: 32000 nM
Estimate against measurement, compound 4: 8.0-fold (0.90 log units) below; the measured number lies above the stated range.
By their numbers in this assay, from the lowest: compounds 1 and 3 (each within the scatter of the next); then compounds 2 and 4 (each within the scatter of the next).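

In this assay, naphthalen-1-yl and 4-fluorophenyl read alike at this position on the core, with no change at the digits printed from compound 2 to compound 4 (within the scatter) even though naphthalen-1-yl brings a second aromatic ring and more heavy atoms. The benzyl compounds stay apart, with a 7.6-fold higher number from compound 3 to compound 4 (0.88 log units; beyond the scatter) and a 7.6-fold higher number from compound 1 to compound 4 (0.88 log units; beyond the scatter) as the steps, so among these four compounds the aryl groups without a benzyl carbon give the higher numbers and the benzyl groups the lower, and none of the four goes against this split. No measured evidence bears on why the numbers divide this way.

Still open, from the compounds shown here alone, is whether the split holds for a pyridine ring or for an aryl group carrying an amine or a carboxylic acid. A longer chain between the core and the outer ring is also untested among the compounds shown.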